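From Methoxycarbonyl to a Diethylamino Side Chain

This account rests on a few compounds, and the source may have more. Where it says the series, first, only, none or still open, it means among the compounds named here.

Among the compounds with values here, in a functional assay on L1210 cells (Mus musculus) for inhibition (on this read-out higher numbers stand for weaker inhibition and lower numbers for stronger inhibition), compound 1 `COC(=O)CNc1ncnc2c1C(=O)C(OC)=CC2=O` gives 1.2 ug/mL and compound 2 `COC(=O)C(Nc1ncnc2c1C(=O)C(OC)=CC2=O)C(C)C` gives 0.825 ug/mL, so compound 1 stands within the scatter of its only measured neighbour. Compound 3 `CCN(CC)CCNc1ncnc2c1C(=O)C(OC)=CC2=O` is unmeasured and differs from compound 1 as follows: (diethylamino)methyl in place of methoxycarbonyl on a saturated chain carbon bound to a nitrogen on an aromatic ring. Within the data shown here, the one measured step, a 1.5-fold lower number from compound 1 to compound 2 (0.16 log units; within the scatter), places isopropyl on the chain and keeps the methoxycarbonyl, so it bears only loosely on this change. No step beyond the scatter is therefore expected in this assay, and the expected step is a 1.3-fold lower number from compound 1 to compound 3 (0.12 log units; within the scatter). The estimate for compound 3 is 0.9 ug/mL, with an expected range from 0.25 ug/mL to 3 ug/mL.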

Compound 3, half-maximal inhibitory concentration: 0.281 ug/mL
The estimate for compound 3 lay 3.2-fold (0.51 log units) above the measured number; the measured number falls inside the stated range.
By their numbers in this assay, from the lowest: compound 3; then compounds 2 and 1 (each within the scatter of the next).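

Exchanging methoxycarbonyl for (diethylamino)methyl gives a 4.3-fold lower number from compound 1 to compound 3 (0.63 log units; beyond the scatter) in this assay, the first step beyond the scatter among these compounds, whereas adding isopropyl gave only a 1.5-fold lower number from compound 1 to compound 2 (0.16 log units; within the scatter). The group on this saturated chain carbon can therefore shift the number, and the methoxycarbonyl is not needed for inhibition of this size. No measurement at hand accounts for this step.

Going by these compounds, whether the step belongs to the diethylamino group or to the loss of the ester remains open. A carboxylic acid, a dimethylamino group or a longer chain in place of 2-(diethylamino)ethyl could help separate the two.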